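Shortening the linker and capping the indole nitrogen

This account rests on a few compounds, and the source may have more. Where it says the series, first, only, none or still open, it means among the compounds named here.

Compound 1 `COc1ccccc1N1CCN(CCCNC(=O)Cc2c[nH]c3ccccc23)CC1`: 513 nM
Compound 2 `COc1ccccc1N1CCN(CCCNC(=O)CCc2c[nH]c3ccccc23)CC1`: 219 nM
Compound 3 `COc1ccccc1N1CCN(CCCNC(=O)c2cc3cccc([N+](=O)[O-])c3[nH]2)CC1`: 646 nM

These values come from an assay on isolated protein (spleen, strain Sprague-Dawley) for antagonist activity at Alpha-1B adrenergic receptor (Rattus norvegicus), with a stated time of 20 min; on this read-out higher numbers stand for weaker binding and lower numbers for tighter binding. Compound 1 sits second highest of the three numbers; compound 3 lies within the usual scatter of it, while compound 2 shows a 2.3-fold lower number from compound 1 to compound 2 (0.37 log units; beyond the scatter), a modest gain. Compound 4 `COc1ccccc1N1CCN(CCCNC(=O)c2cn(C)c3ccccc23)CC1` differs from compound 1 in one spot: 1-methyl-1H-indol-3-yl in place of (1H-indol-3-yl)methyl on a carbonyl carbon. Going by the values given here, only the step from compound 1 to compound 2 speaks to this change, and it runs the opposite way, lengthening rather than removing the chain. Compound 3, with no chain at all, gives no better a number than compound 1. A modest weakening is therefore expected for compound 4, a 1.5-fold higher number from compound 1 to compound 4 (0.16 log units; within the scatter), giving an estimated 750 nM within 250 nM to 2200 nM in this assay.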

Compound 4, dissociation constant: 166 nM
Beside the measured number, compound 4's estimate is 4.5-fold (0.65 log units) above it, outside the stated range (below it).
By their numbers in this assay, from the lowest: compounds 4 and 2 (each within the scatter of the next); then compounds 1 and 3 (each within the scatter of the next).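

On the carbonyl carbon, 1-methyl-1H-indol-3-yl in place of (1H-indol-3-yl)methyl tightens binding in this assay, with a 3.1-fold lower number from compound 1 to compound 4 (0.49 log units; beyond the scatter). Tighter binding here therefore needs neither the chain carbon nor the hydrogen-bond donor of the (1H-indol-3-yl)methyl group, since compound 4 has neither. No measurement available here explains the gain. As far as these compounds go, the change combines two edits, so it remains open whether the gain comes from losing the chain carbon or from adding the methyl. Plain 1H-indol-3-yl or 1-ethyl-1H-indol-3-yl on the same carbonyl carbon would help separate these.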